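The compounds below may be only part of what the source reports. "The series", "measured", "known", "first", "only" and "open" are said of these compounds alone.

Compound 1, `O=C(Nc1cccc(-c2oc3cc(-c4ccc(F)cc4)ccc3c(=O)c2O)c1)c1ccccc1F`, gives 17400 nM in a functional assay on GTL 16 cells for antiproliferative activity against GTL 16 cell line (Homo sapiens), read by CCK-8 assay, with a stated time of 72 h; a higher number here means a weaker inhibitor, a lower number a stronger inhibitor.
Compound 2, `O=C(Nc1cccc(-c2oc3cc(-c4ccc(F)cc4)ccc3c(=O)c2O)c1)c1ccc(F)cc1`, gives 14600 nM in this assay.

Within the data shown here, the numbers for compound 2 and compound 1 sit essentially together: the only measured step, a 1.2-fold lower number from compound 1 to compound 2 (0.08 log units; within the scatter), lies within the scatter, so on these data neither compound can be called the stronger inhibitor. Compound 3, `O=C(Nc1cccc(-c2oc3cc(-c4ccc(F)cc4)ccc3c(=O)c2O)c1)c1ccc(Br)cc1`, differs from compound 2 by a single change: bromo in place of fluoro on an aromatic carbon. Among the measured compounds shown here, no measured step exchanges one halogen for another; the step from compound 1 to compound 2 only replaced 2-fluorophenyl with 4-fluorophenyl on the carbonyl carbon, and the number hardly changed. With nothing in hand that points in either direction, the expectation for compound 3 is a step of about that same small size, a 1.2-fold lower number from compound 2 to compound 3 (0.09 log units; within the scatter), not beyond the scatter. Compound 3 is therefore estimated at 12000 nM, with a range from 5000 nM to 30000 nM.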

Compound 3, half-maximal inhibitory concentration: 25400 nM
Compound 3: middle estimate off by 2.1-fold (0.33 log units), on the low side, and the stated range covers the measured number.
By their numbers in this assay, from the lowest: compounds 2, 1 and 3 (each within the scatter of the next).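

In this assay the exchange of fluoro for bromo on this aromatic carbon, para to a large group, gives a 1.7-fold higher number from compound 2 to compound 3 (0.24 log units; within the scatter) and so stays within the scatter, which makes this the first measured sign that the kind of halogen here may matter little. Moving from the 2-fluorophenyl group to the 4-bromophenyl group gives a 1.5-fold higher number from compound 1 to compound 3 (0.16 log units; within the scatter) and also stays within the scatter, so compounds 1, 2 and 3 cannot be ranked on these data. No outside measurement is available to explain these small steps.

Still open, on these data alone, is whether a different kind of group at this position, such as an amine, a carboxylic acid or a methoxy group, would produce a step beyond the scatter. Also open, as far as these compounds go, is whether changes elsewhere on the shared core would have a larger effect than changes on this ring.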